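Cytotoxicity notes on a nitro-substituted series, hydroxy replacement

The source may report more compounds than this note shows. Statements on the series, on what has been measured and on what is new or still open speak of the compounds shown alone.

Measured so far in an ADME assay on TZM cells (Homo sapiens) for cytotoxicity, read by CellTiter-Glo, with a stated time of 48 h; on this read-out higher numbers stand for lower toxicity in this test and lower numbers for higher toxicity in this test:
- compound 1 `COc1ccc(C2=Cc3ccc(F)cc3C(CC(C)=O)N2c2ccc(O)cc2)cc1`: 60500 nM
- compound 2 `COc1ccc(C2=Cc3ccc([N+](=O)[O-])cc3C(CC(C)=O)N2c2ccc(F)cc2)cc1`: 7700 nM
- compound 3 `COc1ccc(C2=Cc3ccc([N+](=O)[O-])cc3C(CC(C)=O)N2c2ccc(C#N)cc2)cc1`: 15400 nM

Compound 3 holds the second highest of the three numbers in this assay. Its nearest neighbour is compound 2, and the change a 2.0-fold higher number from compound 2 to compound 3 (0.30 log units; within the scatter) lies within the scatter. The furthest is compound 1, whose number in this assay stands higher than that of compound 3 by a margin beyond the scatter.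

The next compound is compound 4 `COc1ccc(C2=Cc3ccc([N+](=O)[O-])cc3C(CC(C)=O)N2c2ccc(O)cc2)cc1`. It differs from compound 3 in one place: hydroxy in place of cyano on an aromatic carbon.

Going by the values given here, no measured step covers this exact exchange. Among the compounds with values here, the only measured step on the same ring, a 2.0-fold higher number from compound 2 to compound 3 (0.30 log units; within the scatter), stayed within the scatter. Compound 1 carries the same hydroxy group as compound 4 but differs from compound 3 in a second place as well, so its value serves only as a rough pointer: compound 1 gives 60500 nM, a higher number than compound 3 gives in this assay. The hydroxy replacement is therefore expected to give a 1.6-fold higher number from compound 3 to compound 4 (0.21 log units; within the scatter), a move toward higher numbers, possibly not beyond the scatter.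

For compound 4 the estimate in this assay is 25000 nM, with a range from 10000 nM to 65000 nM.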

Compound 4, half-maximal cytotoxic concentration: 23500 nM
Compound 4: the middle estimate sits 1.1-fold (0.03 log units) above what was measured; low and high end bracket the measured number.
By their numbers in this assay, from the lowest: compounds 2, 3 and 4 (each within the scatter of the next, the first and the last beyond it); then compound 1.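

In this assay, the change from 4-cyanophenyl to 4-hydroxyphenyl gives a 1.5-fold higher number from compound 3 to compound 4 (0.18 log units; within the scatter), so nitrile and hydroxy cannot be told apart at this position, on an aromatic carbon para to a large group. Going by these compounds alone, the direct exchange of fluoro for hydroxy at the same position gives a 3.1-fold higher number from compound 2 to compound 4 (0.48 log units; beyond the scatter), the first step on this ring to pass beyond the scatter. Nitrile lies within the scatter of both fluoro and hydroxy, and only the two ends of this set of three separate. Within the data shown here, with hydroxy held fixed on that ring, the second site can also be read for the first time, and nitro in place of fluoro gives a 2.6-fold lower number from compound 1 to compound 4 (0.41 log units; beyond the scatter), while no measurement at hand accounts for either shift beyond the scatter.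

Going by these compounds, it remains open whether an amine or a carboxylic acid at this position would stay with hydroxy, nitrile or fluoro in this assay or fall outside their range. On these data alone, the nitro and fluoro exchange is read only with hydroxy on the other ring, so it is unknown whether the same step holds with nitrile or fluoro there.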